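Aryl urea series: trifluoromethyl added to fluorophenyl ring

The source may report more compounds than this note shows. Statements on the series, on what has been measured and on what is new or still open speak of the compounds shown alone.

Compound 1 `C[C@H](NC(=O)Nc1ccccc1F)c1ccccc1` is the starting point of this step. In an ADME assay on the whole organism with Oryza sativa as the target, tested at 10 uM (a higher number here means a weaker effect of the compound at the concentration tested, a lower number a stronger effect), compound 1 gives 65%, the lowest of the two numbers recorded so far; its nearest neighbour is compound 2 `C[C@H](NC(=O)Nc1ccccc1Cl)c1ccccc1`, which in this assay gives 106%. Within the data shown here, the one measured step between these two, a number 41 percentage points higher from compound 1 to compound 2 (beyond the scatter), is the only guide available.

Compound 3 `C[C@H](NC(=O)Nc1cc(C(F)(F)F)ccc1F)c1ccccc1` is not yet measured. It differs from compound 1 in one place: trifluoromethyl in place of hydrogen on an aromatic carbon.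

Among the measured compounds shown here, no measured step covers this exact change. The step of a number 41 percentage points higher from compound 1 to compound 2 (beyond the scatter) concerns a different substituent on the same ring and shows that a single change on this ring can move the read-out a long way upward. Taking that as the nearest precedent, an upward step beyond the scatter is expected, but smaller than the measured one, as the change is not the same; the expected step is a number 17 percentage points higher from compound 1 to compound 3 (beyond the scatter).

Compound 3 is therefore estimated at 82% in this assay, with a range from 52% to 110%.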

Compound 3, a percentage reported as activity, at one concentration (the size of the read-out at that concentration, not a potency): 87%
Compound 3: middle estimate off by 5 percentage points, on the low side, within the range that was stated.
By their numbers in this assay, from the lowest: compound 1; then compound 3; then compound 2.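

In this assay the ring of compound 1 responds at a second place as well: trifluoromethyl in place of hydrogen on an aromatic carbon, meta to a large group and para to a fluoro group, gives a number 22 percentage points higher from compound 1 to compound 3 (beyond the scatter) with the fluoro group left in place. Earlier, the only movement shown on this ring was a number 41 percentage points higher from compound 1 to compound 2 (beyond the scatter) for chloro in place of fluoro, which exchanges one substituent for another, whereas the new change adds a group at a carbon that carried only hydrogen. Both single changes shown for compound 1 therefore raise the number and so weaken the effect at the concentration tested, but nothing at hand bears on why the number rises at this position.

As far as these compounds go, how the read-out moves with a nitrile, a methoxy group or an amine at this same position remains open, as does whether any group here can give a lower number than compound 1, which gives 65%. Also open, from the compounds shown here alone, is whether trifluoromethyl produces an upward step of similar size when chloro stands in place of the fluoro group.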